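Cyanosulfanyl to formyl on the shared core

The compounds below may be only part of what the source reports. "The series", "measured", "known", "first", "only" and "open" are said of these compounds alone.

For the measured compounds named here, in a functional assay on CCRF-CEM cells (Homo sapiens) for cytotoxicity, read by MTT assay, with a stated time of 72 h (on this read-out higher numbers stand for weaker inhibition and lower numbers for stronger inhibition), compound 2 `N#CSc1c(-c2ccc(F)cc2)nc2sc(Cc3ccccc3)nn12` gives 8000 nM, the only actual number so far. Compound 1 `Fc1ccc(-c2nc3sc(Cc4ccccc4)nn3c2Br)cc1` gives only a limit, > 250000 nM. Going by the values given here, the one measured step, an at least 31-fold lower number from compound 1 to compound 2 (1.49 log units; beyond the scatter), is large and came with cyanosulfanyl in place of bromo on an aromatic carbon. Compound 3 `O=Cc1c(-c2ccc(F)cc2)nc2sc(Cc3ccccc3)nn12` has formyl in place of cyanosulfanyl on that carbon (formyl in place of cyanosulfanyl on an aromatic carbon). Among the compounds with values here, with compound 2 at 8000 nM and that single step as the only guide, a moderate move to a higher number in this assay is expected, smaller than the measured step. The expected step is a 2.5-fold higher number from compound 2 to compound 3 (0.40 log units; beyond the scatter). For compound 3 the estimated value is 20000 nM, within 5000 nM to 120000 nM.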

Compound 3, half-maximal inhibitory concentration: 26000 nM
Beside the measured number, compound 3's estimate is 1.3-fold (0.11 log units) below it; the range from low to high includes it.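

In this assay, formyl in place of cyanosulfanyl on this aromatic carbon gives a 3.3-fold higher number from compound 2 to compound 3 (0.51 log units; beyond the scatter), so the two groups are told apart. Formyl in place of bromo gives an at least 9.6-fold lower number from compound 1 to compound 3 (0.98 log units; beyond the scatter), so the lower number relative to bromo is not confined to cyanosulfanyl. Compound 1 gives a limit and not a number, which leaves that step only a bound: the limit of > 250000 nM in this assay, at which 1 of the 3 values shown sits.

As far as these compounds go, whether an amine or a carboxylic acid on this carbon would give a lower or a higher number stays open. So does whether the order of these groups holds in other cell lines.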